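The source may hold more compounds than are shown below. What is called first, only, known or untested is meant among the compounds shown, and "the series" means these compounds.

Measured compounds:
- compound 1 `COc1ccc(Br)cc1-c1nc(N)nc(N)n1`, in a functional assay on the whole organism with Rattus norvegicus as the target, at a dose of 20 mg/kg by the intraperitoneal route (on this read-out higher numbers stand for more inhibition at the one dose given (going by the name of the read-out) and lower numbers for less inhibition), compound 1 gives 49%
- compound 2 `CCc1ccccc1-c1nc(N)nc(N)n1`, compound 2 gives 20%
- compound 3 `CCOc1ccccc1-c1nc(N)nc(N)n1`, compound 3 gives -5%

Compound 3 stands lowest of the three numbers in this assay. Its nearest neighbour is compound 2, which lies higher by the step of a number 25 percentage points lower from compound 2 to compound 3 (beyond the scatter), and compound 1 lies further above it still, beyond the scatter. Within the data shown here, the one step measured within this set, a number 25 percentage points lower from compound 2 to compound 3 (beyond the scatter), is a modest fall when ethoxy replaces ethyl on an aromatic carbon.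

Compound 4 `COc1ccccc1-c1nc(N)nc(N)n1` has not yet been measured. The change from compound 3 to compound 4 is hydrogen in place of methyl on a saturated chain carbon bound to an oxygen on an aromatic ring. Among the measured compounds shown here, no measured step bears directly on this change: the only step known, ethyl to ethoxy, concerns a different exchange, and compound 1 carries methoxy but differs from compound 4 in a second place as well, so the value of compound 1, 49%, can only hint that a methoxy-bearing compound need not be low. For the measured compounds named here, with no direct precedent, the estimate for compound 4 is made cautiously. Compound 4 is expected to give about 15% in this assay, somewhere between -10% and 40%. This means an expected step of a number 20 percentage points higher from compound 3 to compound 4 (beyond the scatter), a moderate rise, though one that could also fall within the scatter.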

Compound 4, a percentage reported as inhibition, in the whole organism at one dose (the size of the read-out at that dose, not a potency): 1%
The estimate for compound 4 lay 14 percentage points above the measured number; measured number inside the range.
By their numbers in this assay, from the lowest: compounds 3 and 4 (each within the scatter of the next); then compound 2; then compound 1.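

In this assay the ethoxy and methoxy compounds cannot be told apart, with a number 6 percentage points higher from compound 3 to compound 4 (within the scatter) as the step when hydrogen replaces methyl on the saturated chain carbon bound to the oxygen. The drop seen earlier on going from ethyl to ethoxy therefore does not depend on that terminal methyl, since methoxy in place of ethyl gives a number 19 percentage points lower from compound 2 to compound 4 (beyond the scatter) and still stands clearly under the ethyl compound. The step for hydrogen in place of bromo on an aromatic carbon, a number 48 percentage points lower from compound 1 to compound 4 (beyond the scatter) as it is printed, is the largest here and shows that methoxy alone does not carry the high number of compound 1, which among these compounds goes with the presence of bromo.

These compounds leave open whether a chloro group or a nitrile on that aromatic carbon would bring a similar rise, and whether an amine or a longer chain in place of the ether would move the number away from the ethers. Nothing at hand accounts for any of these steps.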